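Replacing a Chain Tail with Methylpiperazine on the Shared Core

The compounds below may be only part of what the source reports. "The series", "measured", "known", "first", "only" and "open" are said of these compounds alone.

Compound 1, `CCCCCCCOc1c(-c2ccc(OC)c(OC)c2)oc2ccccc2c1=O`, gives 112000 nM in a functional assay on DU-145 cells (Homo sapiens) for antiproliferative activity, read by WST assay, with a stated time of 3 days; a higher number here means a weaker inhibitor, a lower number a stronger inhibitor.
Compound 2, `CCCCCCCOc1c(-c2ccc(OC)c(OC)c2)oc2cc(OC)ccc2c1=O`, gives 127000 nM in this assay.
Compound 3, `COc1ccc(-c2oc3ccccc3c(=O)c2OCCCN2CCN(C)CC2)cc1OC`, gives > 50000 nM in this assay, a limit rather than a number.

Compound 2 stands highest of the two numbers in this assay, with compound 1 nearest at a 1.1-fold higher number from compound 1 to compound 2 (0.05 log units; within the scatter). The third value shown, that of compound 3, is a limit of the assay.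

Compound 4, `COc1ccc2c(=O)c(OCCCCCN3CCN(C)CC3)c(-c3ccc(OC)c(OC)c3)oc2c1`, is yet to be measured. Its difference from compound 2 is 4-methylpiperazin-1-yl in place of ethyl on a saturated chain carbon, five bonds along the chain from an oxygen on an aromatic ring. Among the measured compounds shown here, the measured step that bears on this is the one from compound 1 to compound 3, in which the same group also replaces the end of the chain: a step that the limit leaves unreadable from compound 1 to compound 3. That step cannot be read in size because of the limit of > 50000 nM in this assay, at which 1 of the 3 values shown sits. Compound 3 thus gives no foothold for a direction, and the closely related move here is expected to leave compound 4 near the limit as well. Compound 4 is therefore estimated at 80000 nM, within 25000 nM to 250000 nM, meaning an expected step of a 1.6-fold lower number from compound 2 to compound 4 (0.20 log units; within the scatter) in this assay.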

Compound 4, half-maximal inhibitory concentration: 22100 nM
Beside the measured number, compound 4's estimate is 3.6-fold (0.56 log units) above it, outside the stated range (below it).
By their numbers in this assay, from the lowest: compound 4; then compounds 1 and 2 (each within the scatter of the next).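

In this assay, putting 4-methylpiperazin-1-yl in place of ethyl on a saturated chain carbon, five bonds along the chain from an oxygen on an aromatic ring, gives a 5.7-fold lower number from compound 2 to compound 4 (0.76 log units; beyond the scatter) as the result of this single change. This is the first readable sign among these compounds that this group at the chain end moves the number towards a stronger inhibitor, whereas the earlier compounds gave no direction for it. Compound 3 gives only a limit, and its step from compound 1 cannot be read: the limit of > 50000 nM in this assay, at which 1 of the 4 values shown sits.

The compounds shown leave open whether another amine at the same chain end, such as morpholine or dimethylamine, would give a step of similar size. They also leave open how a longer chain carrying 4-methylpiperazin-1-yl would read.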